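Adding a methoxy to compound 3

The compounds below may be only part of what the source reports. "The series", "measured", "known", "first", "only" and "open" are said of these compounds alone.

In a functional assay on L1210 cells (Mus musculus) for antiproliferative activity, with a stated time of 48 h (on this read-out higher numbers stand for weaker inhibition and lower numbers for stronger inhibition), compound 3 `COc1ccccc1/C=C/C(=O)c1ccc(N)cc1` gives 12000 nM. Compound 2 `COc1cccc(/C=C/C(=O)c2ccc(N)cc2)c1` gives 22000 nM, within the scatter of compound 3, while compound 1 `C=C(Br)C(=O)Nc1ccc(C(=O)/C=C/c2cccc(OC)c2OC)cc1`, at 1100 nM, has a clearly lower number, which means stronger inhibition. Compound 4 `COc1cccc(/C=C/C(=O)c2ccc(N)cc2)c1OC` differs from compound 3 by a single change, methoxy in place of hydrogen on an aromatic carbon, ortho to a methoxy group: methoxy in place of hydrogen on an aromatic carbon. Among the compounds with values here, no measured pair shows this change alone, so the evidence is thin. Compound 2 at 22000 nM and compound 3 at 12000 nM lie within the scatter of each other, so no step beyond the scatter is expected. The estimated step is small, a 1.2-fold lower number from compound 3 to compound 4 (0.08 log units; within the scatter). The estimate for compound 4 is 10000 nM, with an expected range of 3500 nM to 30000 nM.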

Compound 4, half-maximal inhibitory concentration: 13000 nM
For compound 4 the middle estimate is 1.3-fold (0.11 log units) below the measured one; measured number inside the range.
By their numbers in this assay, from the lowest: compound 1; then compounds 3, 4 and 2 (each within the scatter of the next).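

In this assay, the added methoxy makes no difference beyond the scatter from either single-methoxy compound: a 1.1-fold higher number from compound 3 to compound 4 (0.03 log units; within the scatter), and a 1.7-fold lower number from compound 2 to compound 4 (0.23 log units; within the scatter). Hydrogen in place of (1-bromoethenyl)carbonyl on the nitrogen gives a much larger step, a 12-fold higher number from compound 1 to compound 4 (1.07 log units; beyond the scatter), so among these compounds the clear difference follows that nitrogen group rather than the second methoxy. Nothing here explains either result.

From the compounds shown here alone, whether an ethoxy or an amine at this aromatic carbon would behave like methoxy remains open. So does whether the second methoxy matters when (1-bromoethenyl)carbonyl sits on the nitrogen.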